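The source may report more compounds than this note shows. Statements on the series, on what has been measured and on what is new or still open speak of the compounds shown alone.

In a functional assay on K562 cells (Homo sapiens), read by MTT assay, with a stated time of 72 h (a lower number here means a stronger inhibitor, a higher number a weaker inhibitor), two compounds with a shared core have been measured so far. Compound 1 `Cc1nc(N)c2c(-c3ccccc3)cn([C@@H]3O[C@H](CO)[C@@H](O)[C@H]3O)c2n1` gives > 20000 nM, which is a limit and not a number. Compound 2 `C#Cc1cn([C@@H]2O[C@H](CO)[C@@H](O)[C@H]2O)c2nc(C)nc(N)c12` gives > 20000 nM, which is also a limit. Compound 2 therefore has no exact place on the scale, and the evidence so far is the limit of > 20000 nM in this assay, at which 2 of the 2 values shown sit. Within the data shown here, the only measured change, ethynyl in place of phenyl on an aromatic carbon, is a step that the two limits leave unreadable from compound 1 to compound 2. Compound 3 `Cc1nc(N)c2c(I)cn([C@@H]3O[C@H](CO)[C@@H](O)[C@H]3O)c2n1` makes a further change, with iodo in place of ethynyl on the same aromatic carbon: iodo in place of ethynyl on an aromatic carbon. That single unreadable step offers no size to carry over, so no clear shift in this assay is expected, and another limit is the likeliest result. The expected change is a number no higher from compound 2 to compound 3 (the limit leaves the size open), a rough estimate. For compound 3 the estimated value is 20000 nM, with an expected range from 6000 nM to 40000 nM.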

Compound 3, half-maximal inhibitory concentration: 5120 nM
Estimate against measurement, compound 3: 3.9-fold (0.59 log units) above, and the stated range ends above it.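

In this assay, this aromatic carbon of the five-membered ring proved sensitive to what it carries, which the first two compounds could not show. Iodo in place of ethynyl gives an at least 3.9-fold lower number from compound 2 to compound 3 (0.59 log units; beyond the scatter), and iodo in place of phenyl gives an at least 3.9-fold lower number from compound 1 to compound 3 (0.59 log units; beyond the scatter). Compound 3 is the first with an exact value, while the other two compounds are known only through a limit, so both steps have a minimum size and no upper bound: the limit of > 20000 nM in this assay, at which 2 of the 3 values shown sit.

The compounds shown leave open whether iodo is special at this carbon or whether bromo, chloro or an amine would also give a lower number. They also leave open whether a longer chain on the same carbon would keep the number this low.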